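The compounds below may be only part of what the source reports. "The series", "measured", "known", "first", "only" and "open" are said of these compounds alone.

Compound 1 `O=S(=O)(Nc1ccc2oc(-c3ccccc3)nc2c1)c1cccc(C(F)(F)F)c1` in an ADME assay on HEK293 cells (Homo sapiens) for cytotoxicity, read by resazurin assay, with a stated time of 48 h; on this read-out lower numbers stand for higher toxicity in this test and higher numbers for lower toxicity in this test: > 100000 nM, a limit of the assay.
Compound 2 `Cc1ccccc1S(=O)(=O)Nc1ccc(-c2nc3ccccc3o2)cc1` in this assay: > 100000 nM, also a limit of the assay.
Compound 3 `COc1cccc(S(=O)(=O)Nc2ccc3oc(-c4ccccc4)nc3c2)c1` in this assay: 63000 nM.

Compound 3 thus stands as the only actual number shown; the other two values are limits, and the limit of > 100000 nM in this assay, at which 2 of the 3 values shown sit, marks where they sit. Compound 4 `O=S(=O)(Nc1ccc2oc(-c3ccccc3)nc2c1)c1ccccc1F` differs from compound 3 by 2-fluorophenyl in place of 3-methoxyphenyl on a sulfonyl sulfur. Among the measured compounds shown here, the only measured step, an at least 1.5-fold lower number from compound 1 to compound 3 (0.20 log units; that floor lies within the scatter), alters a group on that same ring and stays within the scatter. Replacing the whole ring gives no basis for a step beyond the scatter, so the expected step is a 1.4-fold higher number from compound 3 to compound 4 (0.15 log units; within the scatter). For compound 4 the estimated value is 90000 nM, with a range from 40000 nM to 200000 nM.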

Compound 4, half-maximal cytotoxic concentration: 72000 nM
Beside the measured number, compound 4's estimate is 1.3-fold (0.10 log units) above it, and the stated range covers the measured number.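

Until now only a group on the ring attached to the sulfonyl sulfur had changed; here the whole ring group on that sulfur is exchanged, and this assay shows a 1.1-fold higher number from compound 3 to compound 4 (0.06 log units; within the scatter) as the result. Among the compounds shown here, this is the first step read between two actual numbers rather than from a limit, and 2-fluorophenyl and 3-methoxyphenyl cannot be told apart in it.

How far the other compounds lie from these two stays unread: the limit of > 100000 nM in this assay, at which 2 of the 4 values shown sit. On these data alone, whether an aliphatic amine or a carboxylic acid in place of the ring group on a sulfonyl sulfur would move the number beyond the scatter also stays open.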